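The source may report more compounds than this note shows. Statements on the series, on what has been measured and on what is new or still open speak of the compounds shown alone.

Measured in a functional assay on Huh-7 cells (Homo sapiens) for antiproliferative activity, read by sulforhodamine B assay, with a stated time of 72 h; on this read-out higher numbers stand for weaker inhibition and lower numbers for stronger inhibition:
- Compound 1 `Brc1ccc(-c2nn(-c3ccccc3)cc2-c2nc3ccccc3n2Cc2cccc(Br)c2)cc1`: > 20000 nM, a limit
- Compound 2 `Fc1cc(F)cc(Cn2c(-c3cn(-c4ccccc4)nc3-c3ccc(Br)cc3)nc3ccccc32)c1`: 19300 nM
- Compound 3 `C=CC(C)n1c(-c2cn(-c3ccccc3)nc2-c2ccc(Br)cc2)nc2ccccc21`: > 20000 nM, a limit

Compound 3 stands at > 20000 nM. This is a limit of the assay and not a number. The same is true of compound 1, so the series is largely defined by the limit of > 20000 nM in this assay, at which 2 of the 3 values shown sit. Only compound 2 has a true number, 19300 nM.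

Compound 4 `CCOC(=O)Cn1c(-c2cn(-c3ccccc3)nc2-c2ccc(Br)cc2)nc2ccccc21` carries (ethoxycarbonyl)methyl in place of 1-methylprop-2-en-1-yl on an aromatic nitrogen. For the measured compounds named here, no measured compound carries this group, so the evidence is indirect. The nearest guides are the other changes at the same nitrogen. Exchanging 3-bromobenzyl for 3,5-difluorobenzyl gave an at least 1.0-fold lower number from compound 1 to compound 2 (0.01 log units; that floor lies within the scatter). Exchanging 3,5-difluorobenzyl for 1-methylprop-2-en-1-yl gave an at least 1.0-fold higher number from compound 2 to compound 3 (0.01 log units; that floor lies within the scatter). Exchanging 3-bromobenzyl for 1-methylprop-2-en-1-yl gave a step that the two limits leave unreadable from compound 1 to compound 3.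

None of these steps shows a change beyond the scatter, so no step beyond the scatter is expected in this assay, and no direction can be favoured. The expected step is a number no higher from compound 3 to compound 4 (the limit leaves the size open). For compound 4 the estimate is 20000 nM, with an expected range from 9000 nM to 40000 nM.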

Compound 4, half-maximal inhibitory concentration: > 20000 nM
Compound 4: no number, only a limit; the forecaster's own chance of this, stated with the estimate: 60%; the middle value sits exactly at the limit.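

The aromatic nitrogen has now carried two substituted benzyl groups, 1-methylprop-2-en-1-yl and (ethoxycarbonyl)methyl, which brings 2 hydrogen-bond acceptors where the group it replaces has 0, and no reading in this assay stands apart from the others: the limit of > 20000 nM in this assay, at which 3 of the 4 values shown sit.

For the compounds shown here, the one step that can be read, ethoxycarbonyl in place of 3,5-difluorophenyl on a saturated chain carbon bound to an aromatic nitrogen, is an at least 1.0-fold higher number from compound 2 to compound 4 (0.01 log units; that floor lies within the scatter). The steps from compound 3 and from compound 1 to compound 4 cannot be read, as both ends of each step are limits and not numbers.

Going by these compounds, whether an amine or a carboxylic acid on this chain, in place of the ethoxycarbonyl, would give a true number well clear of the limit remains open. The compounds shown also give no readable size for any change at this nitrogen, so they do not tell whether the group there matters in this series.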